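One Halogen Swap on a Compound at the Limit

This account rests on a few compounds, and the source may have more. Where it says the series, first, only, none or still open, it means among the compounds named here.

Measured in a functional assay on KB cells (Homo sapiens) for inhibition; on this read-out higher numbers stand for weaker inhibition and lower numbers for stronger inhibition:
- Compound 1 `Nc1nc2cc(Cl)c(Cl)cc2n1Cc1ccc(Cl)cc1`: 45000 nM
- Compound 2 `Clc1ccc(Cn2c(Cl)nc3cc(Cl)c(Cl)cc32)cc1`: > 100000 nM, a limit
- Compound 3 `Clc1ccc(Cn2c(Cl)nc3cc(Cl)c(Cl)cc32)cc1Cl`: > 100000 nM, a limit

Compound 2 has no exact number in this assay, since its > 100000 nM is a limit. The same holds for compound 3, whose > 100000 nM is also a limit. Compound 4 `Fc1ccc(Cn2c(Cl)nc3cc(Cl)c(Cl)cc32)cc1` has not been measured yet. It carries fluoro in place of chloro on an aromatic carbon, para to a large group: fluoro in place of chloro on an aromatic carbon.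

Two measured steps offer some guidance, though neither is the same swap. The first replaces amino with chloro on an aromatic carbon and is beyond the scatter: an at least 2.2-fold higher number from compound 1 to compound 2 (0.34 log units; beyond the scatter). The second replaces hydrogen with chloro on an aromatic carbon, and its size cannot be read: a step that the two limits leave unreadable from compound 2 to compound 3. Neither step gives a measured size for exchanging one halogen for another.

The best remaining guide is the limit of > 100000 nM in this assay, at which 2 of the 3 values shown sit, so compound 4 is expected to stay close to compound 2, quite possibly as another limit. The expected change in this assay is none beyond the scatter: a number no higher from compound 2 to compound 4 (the limit leaves the size open). For compound 4 the estimated value is 100000 nM, with an expected range from 50000 nM to 200000 nM.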

Compound 4, half-maximal inhibitory concentration: > 100000 nM
Compound 4 was reported as a limit; the forecaster's own chance of this, stated with the estimate: 70%; the middle value lies on the limit itself.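

In this assay compound 4 gives > 100000 nM, which is a limit and not a number. Compound 2 also has only a limit, so no step can be read between compound 2 and compound 4. Left open is whether fluoro in place of chloro on this aromatic carbon changes inhibition at all in this assay.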